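A few compounds are considered here, and "the series" means these few. Any claim that something is new, unique, unknown or untested is made for them only; others in the source may bear on it.

Measured in a functional assay on U-87MG ATCC cells (Homo sapiens) for antiproliferative activity; a higher number here means a weaker inhibitor, a lower number a stronger inhibitor:
- compound 1 `CC[C@H](N)C(=O)N1CCc2c(C)c3c(n2-c2ccc(C(N)=O)c(c2)N[C@@H](C)[C@H](C)C1)CC(C)(C)CC3=O`: 45 nM
- compound 2 `Cc1c2c(n3c1CCN(C(=O)C(C)(C)N)C[C@@H](C)[C@H](C)Nc1cc-3ccc1C(N)=O)CC(C)(C)CC2=O`: 39 nM
- compound 3 `Cc1c2c(n3c1CCN(C(=O)C1(N)CCCC1)C[C@@H](C)[C@H](C)Nc1cc-3ccc1C(N)=O)CC(C)(C)CC2=O`: 44 nM

Compound 3, at 44 nM, lies within the scatter of both other compounds, so the three cannot be ranked on these numbers.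

Compound 4 `Cc1c2c(n3c1CCN(C(=O)[C@H](C)O)C[C@@H](C)[C@H](C)Nc1cc-3ccc1C(N)=O)CC(C)(C)CC2=O` keeps the core of compound 3 and changes one group, with 1-hydroxyethyl in place of 1-aminocyclopentyl on a carbonyl carbon.

Among the compounds with values here, three measured steps bear on this change, and all stay within the scatter: a 1.2-fold lower number from compound 1 to compound 2 (0.06 log units; within the scatter), a 1.0-fold lower number from compound 1 to compound 3 (0.01 log units; within the scatter) and a 1.1-fold higher number from compound 2 to compound 3 (0.05 log units; within the scatter). They show that exchanging 1-aminopropyl, 1-amino-1-methylethyl and 1-aminocyclopentyl for one another leaves the number in place. However, all three groups carry an amino group, which 1-hydroxyethyl does not, so no measured step covers this kind of exchange. The flat steps therefore offer only weak support for expecting no change. A moderate move towards a higher number seems more likely than a move towards a lower one, although the data cannot settle the direction.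

The expected size of this change is a 1.8-fold higher number from compound 3 to compound 4 (0.26 log units; within the scatter). The estimate for compound 4 is 80 nM, with an expected range from 25 nM to 300 nM.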

Compound 4, half-maximal inhibitory concentration: 88 nM
Estimate against measurement, compound 4: 1.1-fold (0.04 log units) below; the measured number falls inside the stated range.
By their numbers in this assay, from the lowest: compounds 2, 3, 1 and 4 (each within the scatter of the next, the first and the last beyond it).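

In this assay, within the data shown here, replacing an amino-bearing group on this carbonyl carbon with 1-hydroxyethyl gives a 2.3-fold higher number from compound 2 to compound 4 (0.35 log units; beyond the scatter) and is the only change here to produce a step beyond the scatter, although that step is modest. The other two exchanges give a 2.0-fold higher number from compound 3 to compound 4 (0.30 log units; within the scatter) and a 2.0-fold higher number from compound 1 to compound 4 (0.29 log units; within the scatter) and both stay within the scatter, so the new group separates clearly from only one of the three amino-bearing groups, and the earlier flat steps among those groups did not extend cleanly to this exchange. No measured evidence accounts for this result.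

The change from compound 3 to compound 4 swaps the amino group for a hydroxyl-bearing group and also removes the five-membered carbon ring, and the compounds shown leave open which of these matters at this position. A 1-aminoethyl group or a 1-hydroxycyclopentyl group at the same place would separate these two changes, and the opposite stereocentre of 1-hydroxyethyl remains an open question as well.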